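This account rests on a few compounds, and the source may have more. Where it says the series, first, only, none or still open, it means among the compounds named here.

Compound 3 `Cc1ccc(S(=O)(=O)N[C@@H](CC(=O)NC(C)(C)C)C(=O)NCCNC(=O)c2cc(Cl)ccn2)cc1` is one of three compounds tested for cytotoxicity in an ADME assay on HepG2 cells (Homo sapiens) for cytotoxicity; on this read-out lower numbers stand for an effect already at smaller amounts and higher numbers for an effect only at larger amounts of compound. In this assay compound 3 gives only a limit, > 11000 nM. Compound 1 `Cc1ccc(S(=O)(=O)N[C@@H](CC(=O)NC(C)(C)C)C(=O)NCCNC(=O)NCc2ccccc2)cc1` likewise gives only a limit in this assay, > 11000 nM. Compound 2 `Cc1ccc(S(=O)(=O)N[C@@H](CC(=O)NC(C)(C)C)C(=O)NCCNC(=O)c2cc(Cl)ccc2Cl)cc1` also gives only a limit in this assay, > 11000 nM. Every value shown thus rests on (the limit of > 11000 nM in this assay, at which 3 of the 3 values shown sit), so the steps a step that the two limits leave unreadable from compound 1 to compound 2, a step that the two limits leave unreadable from compound 1 to compound 3 and a step that the two limits leave unreadable from compound 2 to compound 3 cannot be sized. Compound 4 `Cc1ccc(S(=O)(=O)N[C@@H](CC(=O)NC(C)(C)C)C(=O)NCCNC(=O)c2ccc(F)c(F)c2)cc1` differs from compound 3 in one place: 3,4-difluorophenyl in place of 4-chloropyridin-2-yl on a carbonyl carbon. Going by the values given here, none of the measured steps can be read for this change, so no step beyond the scatter is expected. Compound 4 is therefore expected to give about 11000 nM, between 5000 nM and 30000 nM. The expected step is a number no higher from compound 3 to compound 4 (the limit leaves the size open).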

Compound 4, half-maximal effective concentration: > 11000 nM
Compound 4: only a limit was reported; the forecaster's own chance of this, stated with the estimate: 85%; the middle value lies on the limit itself.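

Compound 4, like compound 1, compound 2 and compound 3, gives only a limit, so none of its steps to those compounds can be read: the limit of > 11000 nM in this assay, at which 4 of the 4 values shown sit. In this assay the compounds shown leave open how far any of these groups on the carbonyl carbon changes the effect.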